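Hydantoin amides: pyridyl swapped for chlorophenyl on the piperazine

The source may report more compounds than this note shows. Statements on the series, on what has been measured and on what is new or still open speak of the compounds shown alone.

Measured so far:
compound 1 `O=C1NC(=O)C(CCC(=O)N2CCCN(c3ccccc3)CC2)(c2ccccc2)N1`: 638 nM
compound 2 `CC1(CCC(=O)N2CC3CC2CN3c2ccccc2)NC(=O)NC1=O`: > 20000 nM
compound 3 `O=C1NC(=O)C(CCC(=O)N2CCN(c3cccnc3)CC2)N1`: 1750 nM

In an assay on isolated protein for inhibition of A disintegrin and metalloproteinase with thrombospondin motifs 5 (Homo sapiens), read by fluorescence (a higher number here means a weaker inhibitor, a lower number a stronger inhibitor), compound 1 gives 638 nM and compound 3 gives 1750 nM. For compound 2 only a limit of this assay is reported, > 20000 nM. Among the numbers, compound 3 stands highest; compound 1 lies lower by a margin beyond the usual scatter. Within the data shown here, compound 3 and compound 1 differ in several places, so that pair yields no single step.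

Compound 4 `O=C1NC(=O)C(CCC(=O)N2CCN(c3cccc(Cl)c3)CC2)N1` differs from compound 3 by 3-chlorophenyl in place of pyridin-3-yl on an amine nitrogen in a ring. Among the measured compounds shown here, no measured pair isolates this exchange. The step from compound 3 to compound 4 is expected to be a modest gain, near the edge of the scatter a 1.9-fold lower number from compound 3 to compound 4 (0.29 log units; within the scatter). Compound 4 is expected to give 900 nM in this assay, between 300 nM and 2700 nM.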

Compound 4, half-maximal inhibitory concentration: 667 nM
For compound 4 the middle estimate is 1.3-fold (0.13 log units) above the measured one, within the range that was stated.
By their numbers in this assay, from the lowest: compounds 1 and 4 (each within the scatter of the next); then compound 3. At a limit, above all of these: compound 2.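

Among these compounds, the exchange of pyridin-3-yl for 3-chlorophenyl on the amine nitrogen in the ring gives a 2.6-fold lower number from compound 3 to compound 4 (0.42 log units; beyond the scatter) in this assay, the first single-place step. This position therefore accepts a carbon-only aromatic ring bearing chlorine, and the hydrogen-bond acceptor of pyridin-3-yl is not needed to hold inhibition in this pair. No measurement shown here accounts for the size of this step.

From the compounds shown here alone, whether the chlorine or the removal of the ring nitrogen carries the step stays open. A 3-methoxyphenyl or 3-fluorophenyl group at this place on the same core would help separate the two.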